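A Bromo-to-Methyl Swap on a Shared Core

The compounds below may be only part of what the source reports. "The series", "measured", "known", "first", "only" and "open" are said of these compounds alone.

Measured in a functional assay on C6 cells (Rattus norvegicus) for cytotoxicity, read by MTT assay, with a stated time of 24 h, tested at 12 ug/mL; a higher number here means a weaker effect of the compound at the concentration tested, a lower number a stronger effect:
compound 1 `Cc1nnc(SCC(=O)N/N=c2/scc(-c3ccccc3)n2-c2ccccc2)s1` gives 72.5%
compound 2 `O=C(CSc1nnnn1-c1ccccc1)N/N=c1/scc(-c2ccc(Br)cc2)n1-c1ccccc1` gives 58.6%
compound 3 `Cc1nnc(SCC(=O)N/N=c2/scc(-c3ccc(Cl)cc3)n2-c2ccccc2)s1` gives 76.6%

Among these three numbers compound 2 stands lowest. The nearest of the others is compound 1, whose number lies higher by a gap beyond the scatter, and the furthest is compound 3, higher by a gap that is also beyond the scatter. Going by the values given here, compounds 1 and 3 share a core that differs from that of compound 2, and the one measured step between them, a number 4.1 percentage points higher from compound 1 to compound 3 (within the scatter), lies within the scatter.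

Compound 4 `Cc1ccc(-c2cs/c(=N/NC(=O)CSc3nnnn3-c3ccccc3)n2-c2ccccc2)cc1` differs from compound 2 in one place: methyl in place of bromo on an aromatic carbon. Among the compounds with values here, no measured pair swaps methyl for bromo. Within the data shown here, the only measured step that touches the same six-membered ring is the one from compound 1 to compound 3, and it is small. The step in this assay from compound 2 to compound 4 is therefore expected to be small too, with no clear direction and not beyond the scatter.

Compound 4 is estimated to give 63% in this assay, within a range of 48% to 78%, which means an expected step of a number 4.4 percentage points higher from compound 2 to compound 4 (within the scatter).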

Compound 4, a percentage reported as activity, at one concentration (the size of the read-out at that concentration, not a potency): 55.1%
Estimate against measurement, compound 4: 7.9 percentage points above; the measured number falls inside the stated range.
By their numbers in this assay, from the lowest: compounds 4 and 2 (each within the scatter of the next); then compounds 1 and 3 (each within the scatter of the next).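

In this assay, the change from 4-bromophenyl to 4-methylphenyl on the core of compound 2 gives a number 3.5 percentage points lower from compound 2 to compound 4 (within the scatter) and so leaves the read-out at this concentration essentially unmoved. Going by these compounds alone, until now the only measured change on this ring was a chloro in place of hydrogen on the core of compound 1, a number 4.1 percentage points higher from compound 1 to compound 3 (within the scatter) on a different core, so the result adds a second small step, now with bromo leaving and methyl entering on an aromatic carbon para to a large group; across these two steps, neither change moves the number beyond the scatter, and no compound here goes against that. No experimental evidence is available to explain why this exchange leaves the read-out so little changed.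

The compounds shown leave open whether an amine or a carboxylic acid at this place would stay equally close to compound 2 or move the number beyond the scatter. They also leave open whether the same exchange of bromo for methyl would give an equally small step on the core of compound 1.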